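A few compounds are considered here, and "the series" means these few. Any claim that something is new, unique, unknown or untested is made for them only; others in the source may bear on it.

Three compounds have been measured in a functional assay on the whole organism with Rattus norvegicus as the target; a lower number here means that less compound is needed, a higher number that more compound is needed for the effect:

Compound 1, `CCCCCCCCCc1ccc(CCC(N)(CO)CO)cc1`: 0.03 mg/kg
Compound 2, `CCCCCCCCCCc1ccc(CCC(N)(CO)CO)cc1`: 0.1 mg/kg
Compound 3, `CCCCCCCCCCCCCc1ccc(CCC(N)(CO)CO)cc1`: 0.03 mg/kg

All three share one core and differ only in the length of the saturated chain on the aromatic ring. Compound 3 differs from compound 1 by butyl in place of hydrogen on a saturated chain carbon, nine bonds along the chain from an aromatic carbon, and in this assay this gave no change at the digits printed from compound 1 to compound 3 (within the scatter). Compound 2 differs from compound 1 by methyl in place of hydrogen on a saturated chain carbon, nine bonds along the chain from an aromatic carbon; that change made a 3.3-fold higher number from compound 1 to compound 2 (0.52 log units; beyond the scatter), while a 3.3-fold lower number from compound 2 to compound 3 (0.52 log units; beyond the scatter). The three values therefore do not move in one direction with chain length: compound 2 stands apart, whereas compound 1 and compound 3 cannot be told apart.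

Compound 4, `CCCCCCCCCCCCCCc1ccc(CCC(N)(CO)CO)cc1`, has not yet been measured. It differs from compound 3 by methyl in place of hydrogen on a saturated chain carbon, ten or more bonds along the chain from an aromatic carbon. This is the same kind of change as that made from compound 1 to compound 2, though not the same: the place along the chain differs, as the two descriptions of the change above show. Within the data shown here, the one measured example of this kind of change, a 3.3-fold higher number from compound 1 to compound 2 (0.52 log units; beyond the scatter), was a modest step, yet the larger addition of butyl from compound 1 to compound 3 gave no change at all. With one precedent pointing to a higher number and another pointing nowhere, the value of compound 4 is expected to lie close to that of compound 3, with a slight lean toward a higher number. Compound 4 is thus expected to show a 1.7-fold higher number from compound 3 to compound 4 (0.22 log units; within the scatter). The estimate for compound 4 in this assay is 0.05 mg/kg, expected to fall between 0.02 mg/kg and 0.15 mg/kg.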

Compound 4, dose for 50% inhibition: 1 mg/kg
Beside the measured number, compound 4's estimate is 20-fold (1.30 log units) below it; measured number outside the range, above it.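

In this assay compound 4 stands apart from the three shorter-chain compounds, with a 33-fold higher number from compound 3 to compound 4 (1.52 log units; beyond the scatter), with a 10-fold higher number from compound 2 to compound 4 (1.00 log units; beyond the scatter) and with a 33-fold higher number from compound 1 to compound 4 (1.52 log units; beyond the scatter). Methyl in place of hydrogen raised the number both times, but it did not carry over as a step of fixed size from one core to the other, and the two steps were made at different places along the chain: the same change on two cores in this assay, a 3.3-fold higher number (0.52 log units; beyond the scatter) from compound 1 to compound 2 and a 33-fold higher number (1.52 log units; beyond the scatter) from compound 3 to compound 4, 10-fold (1.00 log units) apart, beyond the scatter of two such steps. Butyl in place of hydrogen did not carry over either, and these pairs show only that the outcome of the same change differed with the core that received it, not what sets the size of the step or how it would run on any other chain: the same change on two cores in this assay, no change at the digits printed (within the scatter) from compound 1 to compound 3 and a 10-fold higher number (1.00 log units; beyond the scatter) from compound 2 to compound 4, 10-fold (1.00 log units) apart, beyond the scatter of two such steps.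

The compounds shown leave open whether the number keeps rising with a chain longer than that of compound 4 or whether the sharp step belongs to this one chain length. They also leave open how the shared core would respond to a chain carrying an ether oxygen or an amide, or to a chain ending in a phenyl ring.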